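A few compounds are considered here, and "the series" means these few. Any claim that something is new, unique, unknown or untested is made for them only; others in the source may bear on it.

Measured so far in a functional assay on MGC-803 cells (Homo sapiens) for antiproliferative activity, read by MTT assay, with a stated time of 48 h; a lower number here means a stronger inhibitor, a higher number a weaker inhibitor 
- compound 1 `COc1ccc(CN(C(=O)CSc2nc3ccccc3s2)c2cc(OC)c(OC)c(OC)c2)cc1O` gives 35 nM 
- compound 2 `COc1ccc(CN(C(=O)CSc2nc3c(C)cccc3s2)c2cc(OC)c(OC)c(OC)c2)cc1O` gives 493 nM 

Compound 2 holds the higher of the two numbers, so it is the weaker inhibitor of the pair. Next comes compound 3 `COc1ccc(CN(C(=O)CSc2nc3cc(Br)ccc3s2)c2cc(OC)c(OC)c(OC)c2)cc1O`, not yet measured. The change from the previous compound is a group of 10 heavy atoms (7 carbon, 1 nitrogen, 1 sulfur, 1 bromine; one five-membered aromatic ring with 2 hetero atoms, one six-membered aromatic ring of carbon only) in place of a group of 10 heavy atoms (8 carbon, 1 nitrogen, 1 sulfur; one five-membered aromatic ring with 2 hetero atoms, one six-membered aromatic ring of carbon only), on a sulfur. The methyl-bearing group leaves and a bromine-bearing group enters on the same sulfur.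

Among the measured compounds shown here, the only measured step that bears on this is a 14-fold higher number from compound 1 to compound 2 (1.15 log units; beyond the scatter), large and beyond the scatter, for methyl in place of hydrogen on an aromatic carbon. For the measured compounds named here, compound 3 no longer has that methyl, but no measured compound carries bromine. Only part of that large step is therefore expected to come back in this assay, in the direction of a lower number, and the uncertainty is wide. The expected step is a 4.1-fold lower number from compound 2 to compound 3 (0.61 log units; beyond the scatter) here. For compound 3 the estimated value is 120 nM, with an expected range from 25 nM to 600 nM in this assay.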

Compound 3, half-maximal inhibitory concentration: 372 nM
Compound 3: middle estimate off by 3.1-fold (0.49 log units), on the low side, within the range that was stated.
By their numbers in this assay, from the lowest: compound 1; then compounds 3 and 2 (each within the scatter of the next).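

In this assay, the loss seen with methyl is not confined to that group: a bromo group on the shared core gives an 11-fold higher number from compound 1 to compound 3 (1.03 log units; beyond the scatter) and so also leaves the compound far from the unsubstituted compound 1. Replacing the 4-methyl-1,3-benzothiazol-2-yl group on the sulfur with the bromine-bearing group gives a 1.3-fold lower number from compound 2 to compound 3 (0.12 log units; within the scatter), so compound 2 and compound 3 cannot be separated in this assay, and bromine recovers none of the activity of compound 1 beyond the scatter. Among the three compounds, both substituted members lie well away from compound 1, with no exception so far, but no measurement here explains that gap.

On these data alone, whether any substituent on these aromatic carbons can match compound 1 remains open, and fluoro, methoxy, hydroxyl or an amine would test this. Also open, as far as these compounds go, is how much the outcome depends on the carbon carrying the group rather than on the group itself, which would need methyl and bromo each compared on the same aromatic carbon.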